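Replacing 3,5-dimethoxyphenyl with 2-hydroxyethyl on an amide

The compounds below may be only part of what the source reports. "The series", "measured", "known", "first", "only" and "open" are said of these compounds alone.

In a functional assay on DU-145 cells (Homo sapiens) for antiproliferative activity, read by sulforhodamine B assay, with a stated time of 3 days (a lower number here means a stronger inhibitor of growth, a higher number a weaker inhibitor of growth), the results so far are:
Compound 1 `O=C(Nc1nccs1)c1cccc(Nc2ncc(F)c(Nc3ccc(F)cc3)n2)c1` gives > 10000 nM as a limit of the assay, not a number
Compound 2 `COc1cc(NC(=O)c2cccc(Nc3ncc(F)c(Nc4ccc(F)cc4)n3)c2)cc(OC)c1` gives 13700 nM as a measured number

Compound 2 stands alone with a real number, since its 13700 nM is the only figure that can be read so far. Compound 1 has only the limit > 10000 nM to show. The next analogue is compound 3 `O=C(NCCO)c1cccc(Nc2ncc(F)c(Nc3ccc(F)cc3)n2)c1` with 2-hydroxyethyl in place of 3,5-dimethoxyphenyl on an amide-type nitrogen, and the counted change is 2-hydroxyethyl in place of 3,5-dimethoxyphenyl on an amide-type nitrogen on the shared core. Only a step that the limit leaves unreadable from compound 1 to compound 2 bears on this change, as it also alters the group on an amide-type nitrogen, yet it gives no size to carry over. With compound 2 at 13700 nM as the only anchor, no clear move in this assay is expected in either direction. A limit rather than a number would be no surprise for compound 3. The expected size is a 1.0-fold higher number from compound 2 to compound 3 (0.01 log units; within the scatter) in this estimate. For compound 3 the estimated value is 14000 nM with a range from 5000 nM to 40000 nM as the expected span.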

Compound 3, concentration for 50% growth inhibition: 13400 nM
Beside the measured number, compound 3's estimate is 1.0-fold (0.02 log units) above it; measured number inside the range.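

In this assay, putting 2-hydroxyethyl in place of 3,5-dimethoxyphenyl on an amide-type nitrogen gives a 1.0-fold lower number from compound 2 to compound 3 (0.01 log units; within the scatter). Among these compounds, this is the first step at this position with a readable size, and it joins two very different groups: one has 10 heavy atoms and a six-membered aromatic ring, while the other has 3 heavy atoms, no ring and a hydrogen-bond donor, yet the two compounds cannot be told apart in this test. Compound 1 gives > 10000 nM, which is a limit of the assay and not a number, so neither of its steps, to compound 2 or to compound 3, can be read: the limit of > 10000 nM in this assay, at which 1 of the 3 values shown sits.

Going by these compounds, it remains open whether any group on this amide-type nitrogen can give a number clearly lower than those of compound 2 and compound 3, for example a chain ending in an amine or a carboxylic acid, or a longer chain carrying the same hydroxyl. Where the 1,3-thiazol-2-yl group of compound 1 truly stands relative to these two compounds also remains unknown.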